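This account rests on a few compounds, and the source may have more. Where it says the series, first, only, none or still open, it means among the compounds named here.

Compound 1 `COc1ccc2c(c1)OC(c1cc(OC)c(OC)c(OC)c1)C(CO)=C2`: in a functional assay for inhibition of nuclear factor NF-kappa-B complex (Homo sapiens) (on this read-out lower numbers stand for stronger inhibition and higher numbers for weaker inhibition), compound 1 gives a limit of the assay, > 50000 nM.
Compound 2 `COc1ccc2c(c1)OC(c1cc(OC)c(OC)c(OC)c1)C(C(=O)N1CCCCC1)=C2`: in this assay compound 2 gives a limit, > 50000 nM.
Compound 3 `COc1ccc2c(c1)OC(c1cc(OC)c(OC)c(OC)c1)C(C(=O)NC(C)C)=C2`: in this assay compound 3 gives a limit, > 50000 nM.

Compound 3 thus stands at the limit of this assay, and so do its two neighbours; all three sit at the limit of > 50000 nM in this assay, at which 3 of the 3 values shown sit. The compound to follow is compound 4 `CNC(=O)C1=Cc2ccc(OC)cc2OC1c1cc(OC)c(OC)c(OC)c1`, which differs from compound 3 by methyl in place of isopropyl on an amide-type nitrogen. Within the data shown here, two measured steps touch the same part of the molecule: the step from compound 2 to compound 3, a step that the two limits leave unreadable from compound 2 to compound 3, also alters the group on the amide-type nitrogen, and the step from compound 1 to compound 3, a step that the two limits leave unreadable from compound 1 to compound 3, installs the isopropylcarbamoyl group in the first place. Neither gives a readable size, since both ends sit at the limit. Among the measured compounds shown here, for compound 4 one therefore expects no step that the assay would resolve, and the change from compound 3 to compound 4 is estimated as a step that the limit leaves unreadable from compound 3 to compound 4. Compound 4 is estimated to remain at the limit, with a value of about 80000 nM, in the range 30000 nM to 300000 nM.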

Compound 4, half-maximal inhibitory concentration: > 50000 nM
Compound 4 ended at the assay's limit; the forecaster's own chance of this, stated with the estimate: 85%; the middle value does not contradict the limit.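

Compound 4 joins compound 1, compound 2 and compound 3 at the assay's limit, so no step among these four compounds can be read: the limit of > 50000 nM in this assay, at which 4 of the 4 values shown sit.

The compounds shown leave open how large any of these steps really is, and whether any group on the carbonyl carbon gives a value inside the measurable range.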